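Swapping a nitrile group for a methyl group

The source may hold more compounds than are shown below. What is called first, only, known or untested is meant among the compounds shown, and "the series" means these compounds.

Values in an ADME assay on L6 cells (Rattus norvegicus) for cytotoxicity, read by resazurin assay, with a stated time of 70 h (a higher number here means a weaker inhibitor, a lower number a stronger inhibitor), for three compounds:
Compound 1 `CC1=CC(C)(C)N(Cc2ccc(C)cc2)c2ccc(O)cc21` gives 8100 nM
Compound 2 `CC(=O)Oc1ccc2c(c1)C(C)=CC(C)(C)N2Cc1ccc(C#N)cc1` gives 29000 nM
Compound 3 `CC(=O)Oc1ccc2c(c1)C(C)=CC(C)(C)N2Cc1cccc(C#N)c1` gives 31000 nM

In this assay compound 3 gives 31000 nM and sits level with compound 2 at the high end of these numbers, while compound 1 lies clearly lower. The next compound is compound 4 `CC(=O)Oc1ccc2c(c1)C(C)=CC(C)(C)N2Cc1ccc(C)cc1` and the change is 4-methylphenyl in place of 3-cyanophenyl on a saturated chain carbon bound to a nitrogen on an aromatic ring in a ring with 4-methylphenyl in place of 3-cyanophenyl.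

Among the measured compounds shown here, the one measured step is a 1.1-fold higher number from compound 2 to compound 3 (0.03 log units; within the scatter) and it shows only that moving the nitrile made no clear difference. For the measured compounds named here, no measured step swaps the nitrile for a methyl group. Compound 1 does carry 4-methylphenyl and gives 8100 nM but its core differs from that of compound 4, so it offers only a loose hint of a lower number. In this assay the expected change is a 1.6-fold lower number from compound 3 to compound 4 (0.19 log units; within the scatter) and a shift of that size would stay within the scatter. Compound 4 is estimated at 20000 nM with an expected range from 8000 nM to 50000 nM.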

Compound 4, half-maximal inhibitory concentration: 21000 nM
Compound 4: middle estimate off by 1.1-fold (0.02 log units), on the low side; measured number inside the range.
By their numbers in this assay, from the lowest: compound 1; then compounds 4, 2 and 3 (each within the scatter of the next).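

In this assay, methyl in place of cyano on an aromatic carbon gives a 1.4-fold lower number from compound 2 to compound 4 (0.14 log units; within the scatter) and 4-methylphenyl in place of 3-cyanophenyl gives a 1.5-fold lower number from compound 3 to compound 4 (0.17 log units; within the scatter) so, on the shared core, neither step shows a clear difference between the nitrile and methyl groups. The acetyl group now stands out as a change that can be read on its own: with 4-methylphenyl present in both compounds, acetyl in place of hydrogen on an oxygen on an aromatic ring gives a 2.6-fold higher number from compound 1 to compound 4 (0.41 log units; beyond the scatter) and this step lies beyond the scatter. No measurement shown here explains these results.

The compounds shown leave open how an amine or a carboxylic acid would behave on the aromatic carbon that carries the nitrile or methyl group. They also leave open whether the acetyl step would be similar in size with a nitrile in place of that methyl group.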